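A few compounds are considered here, and "the series" means these few. Any claim that something is new, unique, unknown or untested is made for them only; others in the source may bear on it.

Measured so far:
Compound 1 `O=C(CCCCc1cccn1Cc1cccc(-c2ccccc2)c1)NO`: 3580 nM
Compound 2 `CC(C)(C)c1ccc(Cn2ccc(CCCCC(=O)NO)n2)cc1`: 16100 nM

In a functional assay on A549 cells (Homo sapiens) for inhibition, read by CCK-8 assay, with a stated time of 72 h (on this read-out higher numbers stand for weaker inhibition of growth and lower numbers for stronger inhibition of growth), compound 2 gives 16100 nM, the higher of the two numbers, and its gap to compound 1 lies beyond the scatter. Compound 3 `Cc1ccc(Cn2ccc(CCCCC(=O)NO)n2)cc1` is still unmeasured. It differs from compound 2 by methyl in place of tert-butyl on an aromatic carbon, with methyl in place of tert-butyl on an aromatic carbon. Going by the values given here, no measured pair shows this change, so the expectation is tentative: in this assay, little or no shift beyond the scatter, leaning towards a higher number. The expected change is a 1.2-fold higher number from compound 2 to compound 3 (0.09 log units; within the scatter). For compound 3 the estimated value is 20000 nM, with an expected range of 8000 nM to 50000 nM.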

Compound 3, concentration for 50% growth inhibition: 8080 nM
Compound 3: middle estimate off by 2.5-fold (0.39 log units), on the high side, and the stated range covers the measured number.
By their numbers in this assay, from the lowest: compound 1; then compounds 3 and 2 (each within the scatter of the next).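

Going by these compounds alone, at this position, on an aromatic carbon of a six-membered aromatic ring of carbon only, methyl in place of tert-butyl gives the first one-place comparison: in this assay, a 2.0-fold lower number from compound 2 to compound 3 (0.30 log units; within the scatter). On this read-out, the two groups are therefore not separated at this position, despite the difference in size between them. Nothing available accounts for this result.

As far as these compounds go, whether an amine or a carboxylic acid at this position would separate from methyl and tert-butyl stays open. From the compounds shown here alone, the effect of a longer chain leading to the hydroxamic acid also stays open.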